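Methyl ester in place of the carboxylic acid of compound 2

The source may hold more compounds than are shown below. What is called first, only, known or untested is meant among the compounds shown, and "the series" means these compounds.

Measured compounds:
compound 1 `Cc1cc(C(=O)N2CCCCc3ccccc32)ccc1CNC(=O)NCC(=O)N(C)C` — 58 nM
compound 2 `Cc1cc(C(=O)N2CCCCc3ccccc32)ccc1CNC(=O)N1CCC[C@H]1C(=O)O` — 680 nM

For the measured compounds named here, compound 1 is the only comparison for compound 2. Going by the values given here, in a functional assay on HEK293 cells for agonist activity at Vasopressin V2 receptor (Homo sapiens), read by a luciferase reporter and cAMP accumulation (a higher number here means that more compound is needed for the effect, a lower number that less compound is needed), compound 2 gives 680 nM, which is the highest of the two numbers known so far; the nearest is compound 1, with 58 nM. Among the compounds with values here, the single measured step, a 12-fold higher number from compound 1 to compound 2 (1.07 log units; beyond the scatter), is large and lies beyond the scatter.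

Compound 3 `COC(=O)[C@@H]1CCCN1C(=O)NCc1ccc(C(=O)N2CCCCc3ccccc32)cc1C` has not been measured. It differs from compound 2 by methyl in place of hydrogen on an oxygen next to a carbonyl group, so that the carboxy group becomes a methoxycarbonyl group. Within the data shown here, no measured step touches this oxygen directly. Among the measured compounds shown here, the only step that bears on it at all is a 12-fold higher number from compound 1 to compound 2 (1.07 log units; beyond the scatter), which shows that the compound carrying no carboxy group, compound 1, gives the lower number. Since compound 3 likewise carries no carboxy group, a step back toward a lower number is expected, though smaller than that one, as only the hydrogen on the oxygen is exchanged.

For compound 3 the estimate is 200 nM, within 60 nM to 700 nM, meaning an expected step of a 3.4-fold lower number from compound 2 to compound 3 (0.53 log units; beyond the scatter).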

Compound 3, half-maximal effective concentration: 100 nM
Estimate against measurement, compound 3: 2.0-fold (0.30 log units) above, within the range that was stated.
By their numbers in this assay, from the lowest: compounds 1 and 3 (each within the scatter of the next); then compound 2.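

In this assay, methyl in place of hydrogen on the oxygen next to the carbonyl group, which turns carboxy into methoxycarbonyl, gives a 6.8-fold lower number from compound 2 to compound 3 (0.83 log units; beyond the scatter). The high number of compound 2 therefore goes with the free carboxy group and not with the pyrrolidine ring that carries it, something a 12-fold higher number from compound 1 to compound 2 (1.07 log units; beyond the scatter) could not separate, as that step changed the whole substituent on the carbonyl carbon. With a 1.7-fold higher number from compound 1 to compound 3 (0.24 log units; within the scatter), 2-(methoxycarbonyl)pyrrolidin-1-yl and ((dimethylcarbamoyl)methyl)amino cannot be told apart in this assay, and nothing available accounts for why the methyl has this effect.

The compounds shown leave open how narrowly this position tolerates change: an ethyl ester, a primary carboxamide, a dimethylcarboxamide or a hydroxymethyl group in place of methoxycarbonyl would each test whether the ester itself matters or only the absence of the carboxy hydrogen. They also leave open whether the same exchange of hydroxy for methoxy would give a step of similar size on the ((dimethylcarbamoyl)methyl)amino side or on another core.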